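The compounds below may be only part of what the source reports. "The series", "measured", "known", "first", "only" and "open" are said of these compounds alone.

Measured compounds:
compound 1 `CN(C)C(=O)c1cc2cnc(Nc3ccc(S(=O)(=O)NCCCCCCN=C=S)cc3)nc2n1C1CCCC1` — 49.5%
compound 2 `CN(C)C(=O)c1cc2cnc(Nc3ccc(S(=O)(=O)NCCCCCCCN=C=S)cc3)nc2n1C1CCCC1` — 32.6%
compound 3 `CN(C)C(=O)c1cc2cnc(Nc3ccc(C(=O)NCCCCCCN=C=S)cc3)nc2n1C1CCCC1` — 35.8%

In a functional assay on A549 cells (Homo sapiens) for inhibition, read by CCK-8 assay, with a stated time of 72 h, tested at 1 uM (on this read-out lower numbers stand for a weaker effect and higher numbers for a stronger effect at the one concentration tested), compound 1 gives 49.5%. The step of a number 16.9 percentage points lower from compound 1 to compound 2 (beyond the scatter) goes with the change (a group of 4 heavy atoms (2 carbon, 1 nitrogen, 1 sulfur; no ring) in place of a group of 3 heavy atoms (1 carbon, 1 nitrogen, 1 sulfur; no ring), on a saturated chain carbon, six bonds along the chain from a sulfonamide nitrogen). Between compound 1 and compound 3 the difference between the two cores is not broken down here; their two values show compound 3 with the lower number. Compound 3 and compound 2 lie within the scatter of each other.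

Compound 4 `CN(C)C(=O)c1cc2cnc(Nc3ccc(C(=O)NCCCCCCCN=C=S)cc3)nc2n1C1CCCC1` carries the change (a group of 4 heavy atoms (2 carbon, 1 nitrogen, 1 sulfur; no ring) in place of a group of 3 heavy atoms (1 carbon, 1 nitrogen, 1 sulfur; no ring), on a saturated chain carbon, six bonds along the chain from an amide-type nitrogen). This is the same kind of change as from compound 1 to compound 2, not the same, since here the place is six bonds along the chain from an amide-type nitrogen rather than from a sulfonamide nitrogen. Going by the values given here, the expected step is a number 11.8 percentage points lower from compound 3 to compound 4 (beyond the scatter), resting only on the single measured step of a number 16.9 percentage points lower from compound 1 to compound 2 (beyond the scatter), so the range is kept wide. Compound 4 is estimated at 24% in this assay, between 10% and 40%.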

Compound 4, a percentage reported as inhibition, at one concentration (the size of the read-out at that concentration, not a potency): 73.7%
Compound 4: the middle estimate sits 49.7 percentage points below what was measured; the whole stated range lies below it.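

Carried to the core of compound 3, with the place now six bonds along the chain from an amide-type nitrogen, the change gives a number 37.9 percentage points higher from compound 3 to compound 4 (beyond the scatter). In this assay, the effect of this change therefore does not carry over between the two cores, and its direction reverses: the same change on two cores in this assay, a number 16.9 percentage points lower (beyond the scatter) from compound 1 to compound 2 and a number 37.9 percentage points higher (beyond the scatter) from compound 3 to compound 4, 54.8 percentage points apart, beyond the scatter of two such steps

Going by these compounds alone, a step measured on one core is thus no guide to the step on the other, although the comparison rests on one pair per core and does not show what underlies the reversal.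

Still open, on these data alone, is whether a longer chain would continue either direction on each core. Also open, as far as these compounds go, is how an amine or a carboxylic acid would fare in place of the changed group.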